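This account rests on a few compounds, and the source may have more. Where it says the series, first, only, none or still open, it means among the compounds named here.

Measured so far in a functional assay on A549 cells (Homo sapiens) for antiproliferative activity, read by MTT assay, with a stated time of 48 h; a lower number here means a stronger inhibitor, a higher number a weaker inhibitor:
- compound 1 `Cn1cc(C2=C(c3nn(CCn4ccnc4)c4ncccc34)C(=O)N(c3ccccc3)C2=O)c2ccccc21`: 43100 nM
- compound 2 `Cn1cc(C2=C(c3nn(CCn4ccnc4)c4ncccc34)C(=O)NC2=O)c2ccccc21`: > 100000 nM

Among the measured compounds shown here, compound 1 carries the only actual number. Compound 2 stands at > 100000 nM, which is a limit of the assay and not a number. The other reading therefore marks (the limit of > 100000 nM in this assay, at which 1 of the 2 values shown sits).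

Compound 3 `Cn1cc(C2=C(c3nn(CCCn4cccc4)c4ncccc34)C(=O)N(c3ccccc3)C2=O)c2ccccc21` keeps the core of compound 1 and changes only the side chain: (1H-pyrrol-1-yl)methyl in place of 1H-imidazol-1-yl on a saturated chain carbon, two bonds along the chain from an aromatic nitrogen. In words, this is (1H-pyrrol-1-yl)methyl in place of 1H-imidazol-1-yl on a saturated chain carbon, two bonds along the chain from an aromatic nitrogen, or 2-(1H-imidazol-1-yl)ethyl to 3-(1H-pyrrol-1-yl)propyl.

For the measured compounds named here, the only measured step, an at least 2.3-fold higher number from compound 1 to compound 2 (0.36 log units; beyond the scatter), is hydrogen in place of phenyl on an amide-type nitrogen in a ring. It lies elsewhere in the molecule and gives no size for a chain change. With compound 1 at 43100 nM as the sole anchor, no step beyond the scatter is expected in this assay, and no direction is favoured. The expected change is a 1.1-fold lower number from compound 1 to compound 3 (0.03 log units; within the scatter). Compound 3 is expected at 40000 nM, with an estimated range of 12000 nM to 100000 nM.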

Compound 3, half-maximal inhibitory concentration: > 100000 nM
Compound 3 was reported as a limit; the forecaster's own chance of this, stated with the estimate: 20%; middle value at least 2.5-fold (0.39 log units) away from the limit.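

In this assay, the side chain proves to be a second position that responds, alongside the amide-type nitrogen: (1H-pyrrol-1-yl)methyl in place of 1H-imidazol-1-yl on a saturated chain carbon, two bonds along the chain from an aromatic nitrogen, gives an at least 2.3-fold higher number from compound 1 to compound 3 (0.36 log units; beyond the scatter). Compound 3 stands at > 100000 nM, which is a limit of the assay and not a number, so only the direction of this step and its lower bound can be read. Compound 1 therefore remains the only compound with an actual number, and the other readings mark one limit: the limit of > 100000 nM in this assay, at which 2 of the 3 values shown sit.

The change alters the ring and the chain together, going from 2-(1H-imidazol-1-yl)ethyl to 3-(1H-pyrrol-1-yl)propyl, so the compounds shown cannot assign the step to either part alone. Among the compounds shown here, open are the single changes that would separate them, 3-(1H-imidazol-1-yl)propyl and 2-(1H-pyrrol-1-yl)ethyl, and whether an amine such as dimethylamino at the end of the chain would keep, improve or lose the reading of compound 1.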